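This account rests on a few compounds, and the source may have more. Where it says the series, first, only, none or still open, it means among the compounds named here.

Measured in a functional assay on NCI-H322 cells (Homo sapiens) for cytotoxicity, read by MTT assay, with a stated time of 24 h; on this read-out higher numbers stand for weaker inhibition and lower numbers for stronger inhibition:
- compound 1 `COc1ccc(/C=C\C(=O)O)c(OCc2cn(-c3ccccc3F)nn2)c1CC=C(C)C`: 45600 nM
- compound 3 `COc1ccc(/C=C\C(=O)O)c(OCc2cn(-c3ccc(C#N)cc3)nn2)c1CC=C(C)C`: 18600 nM
- compound 2 `COc1ccc(-n2cc(COc3c(/C=C\C(=O)O)ccc(OC)c3CC=C(C)C)nn2)cc1`: "not determined" (no result reported)

Compound 3 gives the lower of the two numbers recorded in this assay. Its nearest neighbour is compound 1, and the difference between them is a 2.5-fold lower number from compound 1 to compound 3 (0.39 log units; beyond the scatter), a step that lies beyond the scatter. Compound 2 contributes no number and so cannot be placed.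

Compound 4 `COc1ccc(/C=C\C(=O)O)c(OCc2cn(-c3cccc([N+](=O)[O-])c3)nn2)c1CC=C(C)C` differs from compound 3 in one place: 3-nitrophenyl in place of 4-cyanophenyl on an aromatic nitrogen. Within the data shown here, the only measured step that touches this part of the shared core is the one from compound 1 to compound 3, a 2.5-fold lower number from compound 1 to compound 3 (0.39 log units; beyond the scatter), in which exchanging one substituted phenyl for another on the same aromatic nitrogen gave a modest but real change. Among the measured compounds shown here, no measured pair sets a nitrophenyl against a cyanophenyl, so that step fixes a scale rather than a direction. The step from compound 3 to compound 4 is therefore expected to be no larger than that one, without a firm direction and most likely within the scatter: a 1.1-fold higher number from compound 3 to compound 4 (0.03 log units; within the scatter). Compound 4 is accordingly estimated at 20000 nM in this assay, within a range from 8000 nM to 50000 nM.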

Compound 4, half-maximal inhibitory concentration: 43200 nM
Compound 4: middle estimate off by 2.2-fold (0.33 log units), on the low side, and the stated range covers the measured number.
By their numbers in this assay, from the lowest: compound 3; then compounds 4 and 1 (each within the scatter of the next).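

In this assay, the exchange on this aromatic nitrogen gives a 2.3-fold higher number from compound 3 to compound 4 (0.37 log units; beyond the scatter) and thus shows that the gain seen with the 4-cyanophenyl group is not shared by every substituted phenyl carrying a group with multiple bonds. The further comparison gives a 1.1-fold lower number from compound 1 to compound 4 (0.02 log units; within the scatter) and leaves 3-nitrophenyl and 2-fluorophenyl inseparable here, so among the three aryl groups with numbers, only 4-cyanophenyl stands apart, although all three numbers remain in a narrow band of weak cytotoxicity. No supporting data are available to account for this difference.

Because the exchange from compound 3 to compound 4 alters both the substituent and its place on the phenyl ring, the compounds shown cannot say whether the nitrile, its position, or the two together set the number for compound 3. Also open, going by these compounds, is how far this position can move the number at all, as the series holds no unsubstituted phenyl, no amine or carboxylic acid on the phenyl ring, and no alkyl chain in place of the aryl group.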